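The compounds below may be only part of what the source reports. "The series", "measured", "known", "first", "only" and "open" are said of these compounds alone.

Measured in a functional assay on KB cells (Homo sapiens) for inhibition, with a stated time of 72 h; a higher number here means a weaker inhibitor, a lower number a stronger inhibitor:
- Compound 1 `COc1ccc(S(=O)(=O)N2CCc3cccc(-c4ccc(N)cc4)c32)cc1`: 249 nM
- Compound 2 `COc1ccc(-c2cccc3c2N(S(=O)(=O)c2ccc(OC)cc2)CC3)cc1`: 337 nM
- Compound 3 `COc1ccc(S(=O)(=O)N2CCc3cccc(-c4cccnc4)c32)cc1`: 95.9 nM

Among these three, compound 3 has the lowest number and is the most potent, at 95.9 nM. The next change leads to compound 4 `COc1ccc(S(=O)(=O)N2CCc3cccc(-c4ccccc4)c32)cc1`, with phenyl in place of pyridin-3-yl on an aromatic carbon.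

For the measured compounds named here, two measured steps bear most directly on this change, since both put pyridin-3-yl where a substituted phenyl stood. These are a 2.6-fold lower number from compound 1 to compound 3 (0.41 log units; beyond the scatter) and a 3.5-fold lower number from compound 2 to compound 3 (0.55 log units; beyond the scatter), and both are modest. Methoxy in place of amino gave only a 1.4-fold higher number from compound 1 to compound 2 (0.13 log units; within the scatter), so the two substituted phenyl compounds give a consistent reference level. No unsubstituted phenyl has been measured, so that comparison remains indirect. Leaving pyridin-3-yl for phenyl is therefore expected to move the number upward, by a modest amount similar to or slightly smaller than those two steps. The estimate is a 2.1-fold higher number from compound 3 to compound 4 (0.32 log units; beyond the scatter) in this assay, a step expected to lie near the edge of the scatter. For compound 4, the expected value is 200 nM, with an estimated range of 85 nM to 470 nM.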

Compound 4, half-maximal inhibitory concentration: 120 nM
Estimate against measurement, compound 4: 1.7-fold (0.22 log units) above; the measured number falls inside the stated range.
By their numbers in this assay, from the lowest: compounds 3 and 4 (each within the scatter of the next); then compounds 1 and 2 (each within the scatter of the next).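

In this assay, phenyl in place of pyridin-3-yl gives a 1.3-fold higher number from compound 3 to compound 4 (0.10 log units; within the scatter), so at this aromatic carbon, removing the ring nitrogen and the hydrogen-bond acceptor counted with it leaves no change that can be told from the scatter. The unsubstituted phenyl also allows the substituents to be read directly: hydrogen in place of methoxy gives a 2.8-fold lower number from compound 2 to compound 4 (0.45 log units; beyond the scatter) and hydrogen in place of amino gives a 2.1-fold lower number from compound 1 to compound 4 (0.32 log units; beyond the scatter), so the modest gaps seen earlier between the substituted phenyl compounds and compound 3 go with the methoxy and amino groups rather than with the change of ring atom. No supporting evidence is available to explain these differences.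

The compounds shown leave open whether a fluorine, a nitrile or a carboxylic acid on the phenyl ring would also give a higher number than hydrogen, and whether the outcome would depend on where on that ring the group sits. They also leave open how pyridin-2-yl, pyridin-4-yl or a saturated ring such as piperidine would compare at this aromatic carbon.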